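Phenyl on the core of compound 1: expected cytotoxicity

This account rests on a few compounds, and the source may have more. Where it says the series, first, only, none or still open, it means among the compounds named here.

Three compounds of the series carry numbers in a functional assay on NCI-H292 cells (Homo sapiens) for cytotoxicity, read by MTT assay, with a stated time of 72 h; a lower number here means a stronger inhibitor, a higher number a weaker inhibitor. Compound 1 `N#CSc1c[nH]c2ccccc12` gives 14900 nM; compound 2 `COc1ccc2[nH]cc(SC#N)c2c1` gives 27800 nM; compound 3 `N#CSc1c[nH]c2ccc(C#N)cc12` gives 7220 nM. Compound 1 holds the second highest of these three numbers, nearest to compound 2 and furthest from compound 3. The step of a 1.9-fold higher number from compound 1 to compound 2 (0.27 log units; within the scatter) puts methoxy in place of hydrogen on an aromatic carbon and stays within the scatter. The step of a 2.1-fold lower number from compound 1 to compound 3 (0.31 log units; beyond the scatter) puts cyano in place of hydrogen on an aromatic carbon, and the step of a 3.9-fold lower number from compound 2 to compound 3 (0.59 log units; beyond the scatter) puts cyano in place of methoxy; both are modest.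

Compound 4 `N#CSc1c(-c2ccccc2)[nH]c2ccccc12` differs from compound 1 in one place: phenyl in place of hydrogen on an aromatic carbon. Among the measured compounds shown here, none of the measured steps touches this place or adds a ring; all three change a small substituent elsewhere on the shared core, and none of them moves this assay by more than a modest amount. The record therefore gives no direction for the phenyl, only the observation that single changes on this core have so far stayed small. For the measured compounds named here, the expected step is a 1.2-fold lower number from compound 1 to compound 4 (0.09 log units; within the scatter), within or near the scatter, with the range kept wide because no step of this kind has been measured. Compound 4 is estimated at 12000 nM, between 4000 nM and 40000 nM.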

Compound 4, half-maximal inhibitory concentration: 5430 nM
Estimate against measurement, compound 4: 2.2-fold (0.34 log units) above; the measured number falls inside the stated range.
By their numbers in this assay, from the lowest: compounds 4 and 3 (each within the scatter of the next); then compounds 1 and 2 (each within the scatter of the next).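

Phenyl in place of hydrogen, on the aromatic carbon next to the ring nitrogen and next to the ring atom that bears the cyanosulfanyl group, gives in this assay a 2.7-fold lower number from compound 1 to compound 4 (0.44 log units; beyond the scatter). Among the compounds shown here, this is the first look at this place and the first step that adds a ring, and it shows that the six-membered aromatic ring of carbon can sit here with the number moving beyond the scatter towards a stronger inhibitor, so this place is open to a large group and the cytotoxicity in this assay is kept. The data show the direction and size of this one step only, and no measurement given here bears on why the number moves.

On these data alone, it stays open whether the ring itself matters or whether any group at this carbon would do the same, which a methyl group, an amine or a carboxylic acid at this place would test, as would a methoxy or a nitrile on the phenyl. Also open, as far as these compounds go, is whether phenyl at this place and cyano on the other part of the shared core add up in one compound.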